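Sulfur for oxygen at the ether of compound 3

The source may report more compounds than this note shows. Statements on the series, on what has been measured and on what is new or still open speak of the compounds shown alone.

Compounds measured in an assay on cells for antagonist activity at transient receptor potential cation channel subfamily V member 1 (Homo sapiens), read by FLIPR and calcium flux, with a stated time of 6 min; a higher number here means a weaker inhibitor, a lower number a stronger inhibitor:
compound 1, `CCCCOc1nc(C(C)(C)C)ccc1CNC(=O)C(C)c1ccc(NS(C)(=O)=O)c(F)c1`, 0.9 nM
compound 2, `CC(C)COc1nc(C(C)(C)C)ccc1CNC(=O)C(C)c1ccc(NS(C)(=O)=O)c(F)c1`, 0.6 nM
compound 3, `CC(C(=O)NCc1ccc(C(C)(C)C)nc1OCc1ccc(F)cc1)c1ccc(NS(C)(=O)=O)c(F)c1`, 0.8 nM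

Compound 3 stands second highest of the three numbers, yet its gaps to compound 1 and compound 2 both lie within the scatter, shown by a 1.1-fold lower number from compound 1 to compound 3 (0.05 log units; within the scatter) and a 1.3-fold higher number from compound 2 to compound 3 (0.12 log units; within the scatter). Compound 4, `CC(C(=O)NCc1ccc(C(C)(C)C)nc1SCc1ccccc1)c1ccc(NS(C)(=O)=O)c(F)c1`, differs from compound 3 by benzylsulfanyl in place of (4-fluorobenzyl)oxy on an aromatic carbon. Among the compounds with values here, the steps measured so far, a 1.5-fold lower number from compound 1 to compound 2 (0.18 log units; within the scatter) and the two above, only exchange the group on the oxygen and keep the oxygen itself; no step swaps the oxygen for sulfur or removes the fluorine. In this assay compound 4 is therefore expected near compound 3, with a step of a 1.9-fold higher number from compound 3 to compound 4 (0.27 log units; within the scatter), and an estimate of 1.5 nM within 0.4 nM to 6 nM.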

Compound 4, inhibition constant: 4 nM
The estimate for compound 4 lay 2.7-fold (0.43 log units) below the measured number, and the stated range covers the measured number.
By their numbers in this assay, from the lowest: compounds 2, 3 and 1 (each within the scatter of the next); then compound 4.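

In this assay, exchanges of the group on the oxygen stayed within the scatter, whereas benzylsulfanyl at this position gives steps beyond it (a 5.0-fold higher number from compound 3 to compound 4 (0.70 log units; beyond the scatter); a 6.7-fold higher number from compound 2 to compound 4 (0.82 log units; beyond the scatter); a 4.4-fold higher number from compound 1 to compound 4 (0.65 log units; beyond the scatter)). This position therefore does respond to a change, though only modestly, when the ether oxygen and the fluorine are both gone. Nothing measured here explains this shift. The compounds shown leave open whether the sulfur or the absent fluorine carries the step, which a benzyloxy group would separate. Going by these compounds, how a benzylamino group would read here also remains open.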